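Azaindole for thienopyridine on the amide carbonyl

This account rests on a few compounds, and the source may have more. Where it says the series, first, only, none or still open, it means among the compounds named here.

Two compounds of this series are measured. In an assay for inhibition of Nicotinamide phosphoribosyltransferase (Homo sapiens), read by mass spectrometry, with stated times of 15 min and 30 min (a higher number here means a weaker inhibitor, a lower number a stronger inhibitor), compound 1 `O=C(NCc1ccc(S(=O)(=O)c2ccccc2)cc1)c1cc2ccncc2s1` gives 7 nM and compound 2 `O=C(NCc1ccc(S(=O)(=O)c2cccc(C(F)(F)F)c2)cc1)c1cc2cnccc2[nH]1` gives 8 nM; the two numbers lie within the scatter of each other, so neither stands apart. Compound 3 `O=C(NCc1ccc(S(=O)(=O)c2ccccc2)cc1)c1c[nH]c2ccncc12` is not yet measured. It differs from compound 1 by a group of 9 heavy atoms (7 carbon, 2 nitrogen; one five-membered aromatic ring with 1 hetero atom, one six-membered aromatic ring with 1 hetero atom) in place of a group of 9 heavy atoms (7 carbon, 1 nitrogen, 1 sulfur; one five-membered aromatic ring with 1 hetero atom, one six-membered aromatic ring with 1 hetero atom), on a carbonyl carbon. Among the compounds with values here, no measured pair isolates this exchange, so the expected step of a 1.7-fold higher number from compound 1 to compound 3 (0.23 log units; within the scatter) is small and within the scatter, with no direction to lean on. Compound 3 is therefore estimated at 12 nM in this assay, expected between 4 nM and 40 nM.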

Compound 3, half-maximal inhibitory concentration: 1900 nM
Compound 3: the middle estimate sits 160-fold (2.20 log units) below what was measured; measured number above the stated range.
By their numbers in this assay, from the lowest: compounds 1 and 2 (each within the scatter of the next); then compound 3.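

In this assay, this position, a carbonyl carbon whose other neighbour is an amide-type nitrogen, proves sensitive to the exchange (a 270-fold higher number from compound 1 to compound 3 (2.43 log units; beyond the scatter)). Matching ring counts and 9 heavy atoms therefore do not make these two groups interchangeable; they differ in sulfur against a second nitrogen, and in 0 against 1 hydrogen-bond donors. Nothing at hand accounts for the size of this step.

Still open, on these data alone, is how a simpler group on this carbonyl carbon, such as pyridine or phenyl, would read in this assay. Also open, as far as these compounds go, is whether a methyl group on the ring nitrogen of the entering group would change the result.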